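Fluoro on compound 3: expected growth inhibition

This account rests on a few compounds, and the source may have more. Where it says the series, first, only, none or still open, it means among the compounds named here.

Measured in a functional assay on A2780 cells (Homo sapiens) for inhibition, read by sulforhodamine B assay (on this read-out higher numbers stand for weaker inhibition of growth and lower numbers for stronger inhibition of growth), so far:
- compound 1 `c1ccc(-c2ccc(-c3ccc(-c4nc5ccccc5[nH]4)cc3)cc2)cc1` gives 32100 nM
- compound 2 `Fc1ccc(-c2ccc(-c3ccc(-c4nc5ccccc5[nH]4)cc3)cc2)cc1` gives 48200 nM
- compound 3 `Oc1cccc2[nH]c(-c3ccc(-c4ccc(-c5ccccc5)cc4)cc3)nc12` gives 41000 nM

All three values sit close together. Compound 3 at 41000 nM lies within the scatter of both compound 1 and compound 2, so the series shows no separation so far.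

The next compound is compound 4 `Oc1cccc2[nH]c(-c3ccc(-c4ccc(-c5ccc(F)cc5)cc4)cc3)nc12` and carries fluoro in place of hydrogen on an aromatic carbon, which turns phenyl to 4-fluorophenyl (fluoro in place of hydrogen on an aromatic carbon). The same exchange, made on the core without the hydroxy, gave a 1.5-fold higher number from compound 1 to compound 2 (0.18 log units; within the scatter) and stays within the scatter. The hydroxy exchange gave a 1.3-fold higher number from compound 1 to compound 3 (0.11 log units; within the scatter) and also stays within the scatter. Going by the values given here, neither measured step is large, and no measurement yet shows how the two exchanges behave together. No step beyond the scatter is therefore expected, with at most a slight drift toward higher numbers.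

The expected change is a 1.2-fold higher number from compound 3 to compound 4 (0.07 log units; within the scatter) on this estimate. For compound 4 the estimated value is 48000 nM with an expected range of 27000 nM to 85000 nM in this assay once measured.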

Compound 4, concentration for 50% growth inhibition: 41200 nM
Compound 4: middle estimate off by 1.2-fold (0.07 log units), on the high side, and the stated range covers the measured number.
By their numbers in this assay, from the lowest: compounds 1, 3, 4 and 2 (each within the scatter of the next).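

With the hydroxy present, phenyl to 4-fluorophenyl gives a 1.0-fold higher number from compound 3 to compound 4 (0.00 log units; within the scatter) in this assay, so this exchange, on an aromatic carbon para to a large group, can now be read on two cores, and the readings agree: the same change on two cores in this assay, a 1.5-fold higher number (0.18 log units; within the scatter) from compound 1 to compound 2 and a 1.0-fold higher number (0.00 log units; within the scatter) from compound 3 to compound 4, 1.5-fold (0.17 log units) apart, within the scatter of two such steps.

The hydroxy exchange can likewise be read a second time, with the 4-fluorophenyl already in place, where it gives a 1.2-fold lower number from compound 2 to compound 4 (0.07 log units; within the scatter) and again agrees with its first reading: the same change on two cores in this assay, a 1.3-fold higher number (0.11 log units; within the scatter) from compound 1 to compound 3 and a 1.2-fold lower number (0.07 log units; within the scatter) from compound 2 to compound 4, 1.5-fold (0.17 log units) apart, within the scatter of two such steps.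

Across these four compounds, neither exchange depends on the other beyond the scatter, and fluoro and hydroxy together in compound 4 produce no separation from the rest of the series.

The compounds shown leave open whether any group at this place on the terminal ring can move the number beyond the scatter, and an amine or a carboxylic acid in place of the fluoro would put that to the test. They also leave open whether the hydroxy exchange stays this flat when a methoxy or an amine stands in place of the hydroxy on the core.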